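A few compounds are considered here, and "the series" means these few. Any claim that something is new, unique, unknown or untested is made for them only; others in the source may bear on it.

Compound 1 `CC(C)c1cc(OCC(=O)[C@H](CC(=O)O)NC(=O)[C@@H](NC(=O)COc2cccc3ccccc23)C(C)C)no1` gives in a functional assay on Jurkat cells (Homo sapiens) for inhibition (a lower number here means a stronger inhibitor, a higher number a weaker inhibitor), only the limit > 200000 nM.
Compound 2 `CC(C)[C@H](NC(=O)COc1cccc2ccccc12)C(=O)N[C@@H](CC(=O)O)C(=O)CSc1nc(-c2ccccc2)cs1` gives in this assay only the limit > 200000 nM.
Compound 3 `CC(C)[C@H](NC(=O)COc1cccc2ccccc12)C(=O)N[C@@H](CC(=O)O)C(=O)CSc1nnc(-c2ccccc2)o1` gives in this assay 150000 nM.

Among the measured compounds shown here, compound 3 thus holds the only number in the set; the other two values sit at the limit of > 200000 nM in this assay, at which 2 of the 3 values shown sit. Compound 4 `Cc1nnc(SCC(=O)[C@H](CC(=O)O)NC(=O)[C@@H](NC(=O)COc2cccc3ccccc23)C(C)C)s1` differs from compound 3 by 5-methyl-1,3,4-thiadiazol-2-yl in place of 5-phenyl-1,3,4-oxadiazol-2-yl on a sulfur. The measured steps that touch the group on the sulfur are an at least 1.3-fold lower number from compound 2 to compound 3 (0.12 log units; that floor lies within the scatter) and an at least 1.3-fold lower number from compound 1 to compound 3 (0.12 log units; that floor lies within the scatter); both have floors within the scatter, and none of them exchanges the phenyl for a methyl on the ring. A step of a 1.3-fold higher number from compound 3 to compound 4 (0.12 log units; within the scatter) is therefore expected, nothing beyond the scatter, with a fair chance that compound 4 again reaches only a limit. Compound 4 is estimated at 200000 nM, between 100000 nM and 400000 nM.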

Compound 4, half-maximal inhibitory concentration: 190000 nM
Beside the measured number, compound 4's estimate is 1.1-fold (0.02 log units) above it; the measured number falls inside the stated range.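

In this assay, among the compounds shown here, the exchange on the sulfur gives a 1.3-fold higher number from compound 3 to compound 4 (0.10 log units; within the scatter) and is the first step here with a number at both ends. Going from 11 heavy atoms to 6 in this group thus leaves the value within the scatter. The readings of an at least 1.0-fold lower number from compound 2 to compound 4 (0.02 log units; that floor lies within the scatter) and of an at least 1.0-fold lower number from compound 1 to compound 4 (0.02 log units; that floor lies within the scatter) are floors within the scatter and fix no size. Open, from the compounds shown here alone, is what an amine or a carboxylic acid in place of the methyl would give. Compound 1 and compound 2 also stay unplaced, their values being limits and not numbers: the limit of > 200000 nM in this assay, at which 2 of the 4 values shown sit.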